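Swapping chlorines for fluorines on a chalcone-like pyrazole

The source may hold more compounds than are shown below. What is called first, only, known or untested is meant among the compounds shown, and "the series" means these compounds.

Measured compounds:
compound 1, `COc1cc(-c2cc(/C=C/C(=O)c3ccc(Cl)c(Cl)c3)[nH]n2)cc(OC)c1OC`, 66%
compound 2, `COc1ccc(-c2cc(/C=C/C(=O)c3ccc(N)cc3)[nH]n2)cc1`, -54%
compound 3, `COc1cc(C(=O)/C=C/c2cc(-c3cc(OC)c(OC)c(OC)c3)n[nH]2)cc(OC)c1OC`, -93%

Of the compounds shown here, three sharing a core have been tested in a functional assay on UACC-257 cells (Homo sapiens) for cytotoxicity, read by sulforhodamine B assay, with a stated time of 48 h, tested at 10 uM; on this read-out higher numbers stand for a weaker effect at the one concentration tested and lower numbers for a stronger effect. Compound 1 gives 66%, the highest of the three numbers and so the weakest effect at the one concentration tested. Compound 2 gives -54% and compound 3 gives -93%; both lie far below compound 1, well beyond the scatter of this assay.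

Compound 4, `COc1cc(-c2cc(/C=C/C(=O)c3ccc(F)c(F)c3)[nH]n2)cc(OC)c1OC`, has not yet been measured. It differs from compound 1 in one place: 3,4-difluorophenyl in place of 3,4-dichlorophenyl on a carbonyl carbon. Among the compounds with values here, no measured pair shows what this kind of swap does on this core, so the expectation rests only on compound 1 itself. Since compound 1 already sits at the weak end with 66%, compound 4 is expected to stay close to it, with a step of a number 4 percentage points higher from compound 1 to compound 4 (within the scatter) that is not expected to go beyond the scatter. Compound 4 is therefore estimated at 70%, within a range from 35% to 100%.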

Compound 4, a percentage reported as activity, at one concentration (the size of the read-out at that concentration, not a potency): -18%
Beside the measured number, compound 4's estimate is 88 percentage points above it; the whole stated range lies above it.
By their numbers in this assay, from the lowest: compound 3; then compound 2; then compound 4; then compound 1.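

In this assay, placing 3,4-difluorophenyl where compound 1 has 3,4-dichlorophenyl on a carbonyl carbon gives a number 84 percentage points lower from compound 1 to compound 4 (beyond the scatter), so the effect at the one concentration tested becomes much stronger. This position is therefore far from silent on the shared core: the two groups have the same count of heavy atoms, the same carbon ring and no hydrogen-bond donors, acceptors or net charge, yet exchanging the two halogen atoms alone moves the read-out a long way. Nothing available explains why this exchange has such a large effect.

On these data alone, it remains open how a plain phenyl, a 3,4-dibromophenyl or a 4-fluorophenyl group would behave at this place. Within the data shown here, with only this one swap to read, it is also unclear whether the same exchange would have a similar effect on a different core.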